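The source may hold more compounds than are shown below. What is called first, only, known or untested is meant among the compounds shown, and "the series" means these compounds.

In an ADME assay on J774.A1 cells (Mus musculus) for cytotoxicity, read by MTT assay, with a stated time of 48 h (on this read-out higher numbers stand for lower toxicity in this test and lower numbers for higher toxicity in this test), compound 1 (`COC(=O)c1c([N+](=O)[O-])noc1-c1cccc([N+](=O)[O-])c1`) stands at "not determined" (no result reported) and so offers no single number from which to start. Going by the values given here, the only measured value nearby belongs to compound 2 (`COC(=O)c1c([N+](=O)[O-])noc1-c1ccc(Cl)cc1Cl`), which gives 19700 nM in the same test. Compound 3 (`COC(=O)c1c([N+](=O)[O-])noc1-c1cccc(-c2cnco2)c1`) has yet to be measured. It differs from compound 1 by a single exchange (1,3-oxazol-5-yl in place of nitro on an aromatic carbon) in which 1,3-oxazol-5-yl takes the place of nitro on an aromatic carbon of a six-membered aromatic ring of carbon only, meta to a large group. Among the compounds with values here, no step between measured compounds is available, so the effect of this exchange cannot be read from the data. With no value for compound 1 the expected step in this assay can only be stated loosely: none beyond the usual scatter and in neither direction, taking compound 2 at 19700 nM as the sole anchor. That anchor is thin, so the expected range is kept wide. For compound 3 the estimated value is 20000 nM with an expected range from 7000 nM to 60000 nM in this measurement.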

Compound 3, half-maximal cytotoxic concentration: 19700 nM
Estimate against measurement, compound 3: 1.0-fold (0.01 log units) above; measured number inside the range.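

In this assay, going by these compounds alone, compound 3 gives 19700 nM, but compound 1 offers no single number there, so no step from compound 1 to compound 3 can be read. From the compounds shown here alone, what the exchange of nitro for 1,3-oxazol-5-yl does to this read-out stays open. No other evidence bears on this result.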